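Allyl to propyl on the shared core

A few compounds are considered here, and "the series" means these few. Any claim that something is new, unique, unknown or untested is made for them only; others in the source may bear on it.

In a functional assay on OVCAR-8 cells (Homo sapiens) for antiproliferative activity (a higher number here means a weaker inhibitor, a lower number a stronger inhibitor), compound 1 (`Cn1ncc(Cl)c1-c1cc(C(=O)N[C@@H]2CN[C@H](CCCO)C[C@H]2c2ccc(Cl)c(Cl)c2)oc1Cl`) gives 600 nM, and compound 2 (`C=CC[C@@H]1C[C@@H](c2ccc(Cl)c(Cl)c2)[C@H](NC(=O)c2cc(-c3c(Cl)cnn3C)c(Cl)o2)CN1`) gives 990 nM. Going by the values given here, compound 2 therefore stands within the scatter of compound 1, the only other measured member of the series, and the two values cannot be separated.

Compound 3 (`CCC[C@@H]1C[C@@H](c2ccc(Cl)c(Cl)c2)[C@H](NC(=O)c2cc(-c3c(Cl)cnn3C)c(Cl)o2)CN1`) remains unmeasured. Its difference from compound 2 is ethyl in place of vinyl on a saturated chain carbon bound to a saturated ring carbon. In words, this is ethyl in place of vinyl on a saturated chain carbon bound to a saturated ring carbon, which also reads as allyl to propyl.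

Among the compounds with values here, only one measured step bears on this change: a 1.7-fold higher number from compound 1 to compound 2 (0.22 log units; within the scatter). It put vinyl in place of 2-hydroxyethyl at a place described in the same words. With that single small step as the guide, no step beyond the scatter is expected in this assay. The data hold no direct comparison of a saturated chain with an unsaturated one. The estimated step is a 1.2-fold lower number from compound 2 to compound 3 (0.09 log units; within the scatter). Compound 3 is expected at 800 nM, with an estimated range of 400 nM to 1700 nM.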

Compound 3, half-maximal inhibitory concentration: 1620 nM
Compound 3: middle estimate off by 2.0-fold (0.31 log units), on the low side, within the range that was stated.
By their numbers in this assay, from the lowest: compounds 1, 2 and 3 (each within the scatter of the next, the first and the last beyond it).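

Working notes on the chain position, in this assay: the saturated and unsaturated chains can now be compared directly, and ethyl in place of vinyl gives a step within the scatter (a 1.6-fold higher number from compound 2 to compound 3 (0.21 log units; within the scatter)), so removing the double bond outside aromatic rings produces no separable difference here. Going by these compounds alone, the same position also gives the only step of the three that lies beyond the scatter (a 2.7-fold higher number from compound 1 to compound 3 (0.43 log units; beyond the scatter)), a modest one, with hydrogen in place of hydroxy on a saturated chain carbon, three bonds along the chain from a saturated ring carbon, while compound 2 remains within the scatter of both compound 1 and compound 3. No supporting data bear on the origin of either step.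

The compounds shown leave open whether an amine or a carboxylic acid at the end of the chain would separate from hydroxy in this assay. They also leave open whether a longer chain, with or without a terminal hydroxy, would extend or reverse the modest step seen between the propyl and hydroxypropyl compounds.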